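Swapping methoxy for cyano on a sulfonyl aryl ring

The source may report more compounds than this note shows. Statements on the series, on what has been measured and on what is new or still open speak of the compounds shown alone.

Of the compounds shown here, three sharing one core have been measured in an ADME assay on microsomes from liver (Homo sapiens) for metabolic stability, tested at 2.5 uM; a higher number here means faster removal of the compound, a lower number slower removal. Compound 1 `COc1ccc(-c2c(S(=O)(=O)c3cccc(C#N)c3)cnc3cc(F)ccc23)cc1` gives 0.92 mL/min, compound 2 `O=S(=O)(c1ccc(F)cc1)c1cnc2cc(F)c(Cl)cc2c1-c1ccc(Cl)cc1` gives 0.01 mL/min, and compound 3 `COc1cccc(S(=O)(=O)c2cnc3cc(F)ccc3c2-c2cccc(Cl)c2)c1` gives 2.97 mL/min. Compound 3 therefore stands highest of the three, with compound 1 nearest to it and compound 2 furthest away, both gaps lying beyond the usual scatter.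

The next compound, compound 4 `N#Cc1cccc(S(=O)(=O)c2cnc3cc(F)ccc3c2-c2cccc(Cl)c2)c1`, differs from compound 3 in a single place: cyano in place of methoxy on an aromatic carbon. The change sits on an aromatic carbon of a six-membered aromatic ring of carbon only, meta to a large group.

Within the data shown here, no measured pair shows this exact change, so the expectation rests on compound 1, which also carries a cyano group in this position and gives 0.92 mL/min in this assay. The step from compound 3 to compound 4 is expected to be a drop, estimated at a 2.5-fold lower number from compound 3 to compound 4 (0.39 log units; beyond the scatter). Compound 4 is accordingly expected to give about 1.2 mL/min, within a range from 0.5 mL/min to 3 mL/min.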

Compound 4, intrinsic clearance in a liver preparation (reported as CLH), per the amount of preparation that the assay uses: 0.99 mL/min
Estimate against measurement, compound 4: 1.2-fold (0.08 log units) above; low and high end bracket the measured number.
By their numbers in this assay, from the lowest: compound 2; then compounds 1 and 4 (each within the scatter of the next); then compound 3.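

In this assay the swap of methoxy for cyano on this ring can now be read directly: the step is a 3.0-fold lower number from compound 3 to compound 4 (0.48 log units; beyond the scatter) and lies beyond the scatter, so the compound with cyano is removed more slowly, though the drop is modest. With cyano held in place, changing 4-methoxyphenyl to 3-chlorophenyl gives a 1.1-fold higher number from compound 1 to compound 4 (0.03 log units; within the scatter) and stays within the scatter, so this pair shows no real difference in removal. Nothing measured here explains why the cyano compound is removed more slowly.

Among these compounds, only one swap at this ring position can be read, so whether an amine, a carboxylic acid or a longer chain such as ethoxy would behave like cyano stays open. As far as these compounds go, it is also open whether the drop from methoxy to cyano would hold with a group other than 3-chlorophenyl on the shared core.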